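Hydrazone aryl exchange on the shared core, compound 3

The source may hold more compounds than are shown below. What is called first, only, known or untested is meant among the compounds shown, and "the series" means these compounds.

Measured in a functional assay on the whole organism (Abdomen, strain NMRI) for inhibition, with Mus musculus as the target, in the writhing test, with a stated time of 30 min, at a dose of 10 mg/kg; on this read-out lower numbers stand for less inhibition and higher numbers for more inhibition at the one dose given (going by the name of the read-out):
compound 1 `O=C(N/N=C/c1ccccc1)c1cccnc1Nc1cccc(C(F)(F)F)c1` gives 66.2%
compound 2 `COc1ccc(/C=N/NC(=O)c2cccnc2Nc2cccc(C(F)(F)F)c2)cc1OC` gives 80.7%

Among the compounds with values here, compound 2 holds the higher of the two numbers; the one measured step, a number 14.5 percentage points higher from compound 1 to compound 2 (beyond the scatter), is the whole of what is known about the aryl group on the carbon with a double bond to nitrogen. Compound 3 `O=C(N/N=C/c1cccnc1)c1cccnc1Nc1cccc(C(F)(F)F)c1` carries the change (pyridin-3-yl in place of 3,4-dimethoxyphenyl on a carbon with a double bond to nitrogen). Within the data shown here, no measured step covers this exchange; the only step, from phenyl to 3,4-dimethoxyphenyl, lies beyond the scatter but points in no direction for a pyridin-3-yl. Compound 3 is therefore expected to sit between the two measured compounds, a step of a number 12.7 percentage points lower from compound 2 to compound 3 (beyond the scatter) downward, with an estimate of 68% and a range of 50% to 85%.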

Compound 3, a percentage reported as inhibition, in the whole organism at one dose (the size of the read-out at that dose, not a potency): 51.4%
Estimate against measurement, compound 3: 16.6 percentage points above, within the range that was stated.
By their numbers in this assay, from the lowest: compound 3; then compound 1; then compound 2.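

In this assay the exchange to pyridin-3-yl gives a number 29.3 percentage points lower from compound 2 to compound 3 (beyond the scatter) and also a number 14.8 percentage points lower from compound 1 to compound 3 (beyond the scatter), so the aryl group on the carbon with a double bond to nitrogen can move this read-out down as well as up. Phenyl in compound 1 is therefore not the low end at this position, as compound 3 ranks lowest of the three. Nothing available explains these steps.

Open, as far as these compounds go, is how a pyridin-4-yl, a single methoxy-bearing phenyl or a phenyl carrying a carboxylic acid would rank here. From the compounds shown here alone, whether the ranking holds at other doses also remains open.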